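The source may report more compounds than this note shows. Statements on the series, on what has been measured and on what is new or still open speak of the compounds shown alone.

Three compounds sharing one core have been measured in a functional assay on OVCAR-3 cells (Homo sapiens) for inhibition, read by MTT assay, with a stated time of 24 h; a higher number here means a weaker inhibitor, a lower number a stronger inhibitor:

Compound 1, `CCc1ccc(/C=C/[C@@H]2CCCCN2)cc1`, gives 5.07 ug/mL.
Compound 2, `FC(F)(F)c1ccc(/C=C/[C@@H]2CCCCN2)cc1`, gives 0.99 ug/mL.
Compound 3, `C(=C/[C@@H]1CCCCN1)\c1ccccc1`, gives 10.5 ug/mL.

Compound 3 carries only hydrogen on the aromatic carbon where the other two carry a group, and it stands with the highest number of the three. The step of a 2.1-fold higher number from compound 1 to compound 3 (0.32 log units; beyond the scatter) is modest, while the step of an 11-fold higher number from compound 2 to compound 3 (1.03 log units; beyond the scatter) is large; in both cases the compound with a group on that carbon gave the lower number.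

Compound 4, `COc1ccc(/C=C/[C@@H]2CCCCN2)cc1`, differs from compound 3 by methoxy in place of hydrogen on an aromatic carbon. Among the measured compounds shown here, no methoxy analogue has been measured, so the only guidance comes from the two steps just named, in which a group on that carbon was swapped for hydrogen and the number rose. Going the other way, from hydrogen to a group, is expected to lower the number, most likely by a modest amount rather than the large one seen with trifluoromethyl, and methoxy is a group not yet tested here, so the spread is wide. Compound 4 is estimated at 5 ug/mL, with a range from 2 ug/mL to 12 ug/mL. The expected step is a 2.1-fold lower number from compound 3 to compound 4 (0.32 log units; beyond the scatter).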

Compound 4, half-maximal inhibitory concentration: 3.31 ug/mL
For compound 4 the middle estimate is 1.5-fold (0.18 log units) above the measured one; the range from low to high includes it.
By their numbers in this assay, from the lowest: compound 2; then compounds 4 and 1 (each within the scatter of the next); then compound 3.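

In this assay the change of hydrogen to methoxy gives a 3.2-fold lower number from compound 3 to compound 4 (0.50 log units; beyond the scatter) and so adds a third group on this aromatic carbon that gives a lower number than hydrogen, with no compound shown going against that pattern. Not every group does this equally, though: methoxy in place of trifluoromethyl gives a 3.3-fold higher number from compound 2 to compound 4 (0.52 log units; beyond the scatter) and so gives back part of what trifluoromethyl gained. Methoxy in place of ethyl gives a 1.5-fold lower number from compound 1 to compound 4 (0.19 log units; within the scatter) and so leaves these two groups unresolved, even though methoxy brings in an oxygen atom and ethyl has none.

Nothing available explains the order of these groups. On these data alone, it also remains open whether an amine, a carboxylic acid or a longer carbon chain on this aromatic carbon would give a number lower than hydrogen does, or whether any group would pass trifluoromethyl.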